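The compounds below may be only part of what the source reports. "The series", "measured", "known", "first", "only" and "open" are said of these compounds alone.

Three compounds share one core and differ only in the group on one aromatic nitrogen. In an assay on isolated protein for inhibition of Gonadotropin-releasing hormone receptor (Rattus norvegicus) (on this read-out lower numbers stand for stronger inhibition and higher numbers for weaker inhibition), compound 1 `CCCCn1c(SCc2cc([N+](=O)[O-])ccc2OC)nc2cc(NC(=O)NC(C)(C)C)ccc21` gives 330 nM, compound 2 `COc1ccc([N+](=O)[O-])cc1CSc1nc2cc(NC(=O)NC(C)(C)C)ccc2n1Cc1ccccc1` gives 160 nM, and compound 3 `COc1ccc([N+](=O)[O-])cc1CSc1nc2cc(NC(=O)NC(C)(C)C)ccc2n1Cc1ccccn1` gives 670 nM, the highest number of the three and so the weakest inhibition here. The measured steps were a 2.1-fold lower number from compound 1 to compound 2 (0.31 log units; beyond the scatter), a 2.0-fold higher number from compound 1 to compound 3 (0.31 log units; beyond the scatter) and a 4.2-fold higher number from compound 2 to compound 3 (0.62 log units; beyond the scatter). Compound 4 `COc1ccc([N+](=O)[O-])cc1CSc1nc2cc(NC(=O)NC(C)(C)C)ccc2n1C(C)C` carries isopropyl in place of (pyridin-2-yl)methyl on an aromatic nitrogen. Among the measured compounds shown here, no measured step swaps a ring-bearing group for a small branched chain, but compound 1 at 330 nM, with its plain chain, sits between the two ring-bearing compounds, so a small chain is expected to land near it. The expected step is therefore a 1.9-fold lower number from compound 3 to compound 4 (0.28 log units; within the scatter). Compound 4 is estimated at 350 nM, within a range from 150 nM to 900 nM.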

Compound 4, half-maximal inhibitory concentration: 62 nM
Compound 4: the middle estimate sits 5.6-fold (0.75 log units) above what was measured, and the stated range ends above it.
By their numbers in this assay, from the lowest: compound 4; then compound 2; then compound 1; then compound 3.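

In this assay, the branched isopropyl group gives a lower number than each of the other groups on this aromatic nitrogen, with an 11-fold lower number from compound 3 to compound 4 (1.03 log units; beyond the scatter), a 2.6-fold lower number from compound 2 to compound 4 (0.41 log units; beyond the scatter) and a 5.3-fold lower number from compound 1 to compound 4 (0.73 log units; beyond the scatter). The last step compares two groups without a ring, so a ring's absence alone does not account for the low number; the branched chain gives a lower number than the straight butyl. Nothing available explains this difference.

As far as these compounds go, whether methyl, cyclopropyl or tert-butyl would give a still lower number remains open.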